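The source may report more compounds than this note shows. Statements on the series, on what has been measured and on what is new or still open speak of the compounds shown alone.

Values in an ADME assay for permeability, using PAMPA, with a stated time of 3 h; a lower number here means that the compound crosses the layer more slowly, a higher number that the compound crosses the layer faster:
Compound 1 `O=C(Nc1cccc(Cl)c1)c1cc(Cl)ccc1O`: 8.6 10^-6 cm/s
Compound 2 `O=C(Nc1cccc(F)c1)c1cc(Cl)ccc1O`: 3.7 10^-6 cm/s
Compound 3 `O=C(Nc1cccc(C(F)(F)F)c1)c1cc(Cl)ccc1O`: 4.2 10^-6 cm/s

In this assay, compound 3 gives 4.2 10^-6 cm/s, which lies within the scatter of the number for compound 2. Compound 1 stands clear of both. Compound 4 `CC(C)(C)c1cccc(NC(=O)c2cc(Cl)ccc2O)c1` carries tert-butyl in place of trifluoromethyl on an aromatic carbon, meta to a large group (tert-butyl in place of trifluoromethyl on an aromatic carbon). Going by the values given here, no measured compound carries tert-butyl, so the estimate rests on the three steps that exchange one group at this place for another. The data show a 2.3-fold lower number from compound 1 to compound 2 (0.37 log units; beyond the scatter) and a 2.0-fold lower number from compound 1 to compound 3 (0.31 log units; beyond the scatter), both modest, and a 1.1-fold higher number from compound 2 to compound 3 (0.06 log units; within the scatter), which stays within the scatter. These steps suggest that a further exchange here should also be small, and no clear direction can be drawn from them. The expected change is a 1.2-fold higher number from compound 3 to compound 4 (0.08 log units; within the scatter), which would not be beyond the scatter. For compound 4 the estimated value is 5 10^-6 cm/s. The expected range for compound 4 runs from 2.5 10^-6 cm/s to 10 10^-6 cm/s.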

Compound 4, apparent permeability: 18.7 10^-6 cm/s
Beside the measured number, compound 4's estimate is 3.7-fold (0.57 log units) below it; the measured number lies above the stated range.
By their numbers in this assay, from the lowest: compounds 2 and 3 (each within the scatter of the next); then compound 1; then compound 4.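

In this assay this exchange gives the widest steps seen at this position: a 4.5-fold higher number from compound 3 to compound 4 (0.65 log units; beyond the scatter) and a 5.1-fold higher number from compound 2 to compound 4 (0.70 log units; beyond the scatter) and also a 2.2-fold higher number from compound 1 to compound 4 (0.34 log units; beyond the scatter), so compound 4 stands clear of all three earlier compounds. The position is therefore less indifferent to exchange than the small step between fluoro and trifluoromethyl alone implied, and chloro no longer gives the highest number. Trifluoromethyl and tert-butyl have the same count of heavy atoms and still stand clearly apart, so that count alone does not order these compounds. Nothing available here explains the rise seen with tert-butyl. The compounds shown leave open how an amine, a carboxylic acid or a longer chain would behave at this position, and whether tert-butyl would give a similar step elsewhere on the shared core.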